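Adding chloro to compound 3: an expected small step

The source may hold more compounds than are shown below. What is called first, only, known or untested is meant among the compounds shown, and "the series" means these compounds.

Values in a functional assay on A549 cells (Homo sapiens) for antiproliferative activity, read by MTT assay, with a stated time of 48 h (on this read-out higher numbers stand for weaker inhibition and lower numbers for stronger inhibition), are as follows
- compound 1 `COc1ccc(N(C)c2ccnc(Cl)n2)cc1Cl` gives 621 nM
- compound 2 `COc1ccc(N(C)c2ccnc(Cl)n2)cc1O` gives 381 nM
- compound 3 `COc1ccc(N(C)c2cc(C)nc(C)n2)cc1` gives 277 nM

In this assay compound 3 gives 277 nM and so stands within the scatter of compound 2, which gives 381 nM in the same test. Compound 1 gives 621 nM and stands higher than compound 3 by more than the scatter.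

Compound 4 `COc1ccc(N(C)c2cc(C)nc(C)n2)cc1Cl` keeps the rest of compound 3 and takes chloro in place of hydrogen on an aromatic carbon, ortho to a methoxy group, a change counted as chloro in place of hydrogen on an aromatic carbon here.

For the measured compounds named here, no measured step isolates this change. Going by the values given here, the one step at such a carbon is a 1.6-fold lower number from compound 1 to compound 2 (0.21 log units; within the scatter) and it exchanges chloro for hydroxy, not for hydrogen. Compound 1 and compound 2 also differ from compound 3 elsewhere in the core, so the gap between compound 1 and compound 3 cannot be assigned to chloro alone. The data therefore give no ground for a large change, and no step beyond the scatter is expected in this assay, with only a slight lean towards a higher number. The expected step is a 1.2-fold higher number from compound 3 to compound 4 (0.09 log units; within the scatter) on this estimate. Compound 4 is estimated at 340 nM with an expected range from 120 nM to 950 nM in this test.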

Compound 4, half-maximal inhibitory concentration: 780 nM
The estimate for compound 4 lay 2.3-fold (0.36 log units) below the measured number, within the range that was stated.
By their numbers in this assay, from the lowest: compounds 3, 2, 1 and 4 (each within the scatter of the next, the first and the last beyond it).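

In this assay, for the compounds shown here, chloro in place of hydrogen on an aromatic carbon, ortho to a methoxy group, gives a 2.8-fold higher number from compound 3 to compound 4 (0.45 log units; beyond the scatter), the first step that isolates this change and one that lies beyond the scatter, towards weaker inhibition. The only earlier step at such a carbon, a 1.6-fold lower number from compound 1 to compound 2 (0.21 log units; within the scatter), put hydroxy in place of chloro on another core and stayed within the scatter, so it had not shown that a single change at this carbon can move the number by more than the scatter; the new step shows this on the core of compound 3, where a single chlorine atom is all that enters. No measurement among these data gives a reason for the step, so it stands as an observation without an explanation.

The compounds shown leave open how fluoro, an amine or a carboxylic acid at this carbon would read, and so whether the step is particular to chloro or would follow any group that replaces hydrogen here. On these data alone, it also remains open whether chloro in place of hydrogen would give a step of like size on the core of compound 1.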